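A few compounds are considered here, and "the series" means these few. Any claim that something is new, unique, unknown or untested is made for them only; others in the source may bear on it.

Three compounds share one core, and all were tested in a functional assay on HEK293 cells for agonist activity at G-protein coupled receptor 39 (Mus musculus), read by inositol phosphate accumulation; on this read-out lower numbers stand for an effect already at smaller amounts and higher numbers for an effect only at larger amounts of compound. Going by the values given here, compound 1 `CNc1nc(NCC(C)(C)C)cc(-c2ccccn2)n1` gives 365 nM, and compound 2 `CNc1nc(NCc2ccncc2)cc(-c2ccccn2)n1` gives 304 nM; the only step among them that changes a single place is a 1.2-fold lower number from compound 1 to compound 2 (0.08 log units; within the scatter). Compound 3 `CNc1nc(NCc2ccc(NS(C)(=O)=O)cc2)cc(-c2ccccn2)n1` gives 8 nM, which is the lowest of the three numbers, and its gap to both compound 2 and compound 1 is beyond the scatter.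

Compound 4 `CNc1nc(NCc2ccc(Cl)cc2)cc(-c2ccccn2)n1` is built from compound 3 by one change: chloro in place of methanesulfonamido on an aromatic carbon. The new group sits on an aromatic carbon of a six-membered aromatic ring of carbon only, para to a large group.

Among the compounds with values here, no measured step covers this exact exchange. Within the data shown here, the one measured step, from compound 1 to compound 2, concerns a different part of the molecule and stays within the scatter, so it says nothing about the methanesulfonamido group. Among the measured compounds shown here, what can be read is that compound 3, the only compound carrying that group, sits far below compound 1 and compound 2, so its removal is expected to raise the number, though by how much remains open; the estimated step of a 7.5-fold higher number from compound 3 to compound 4 (0.88 log units; beyond the scatter) reflects this. Compound 4 is therefore expected to give about 60 nM, within a range from 15 nM to 250 nM.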

Compound 4, half-maximal effective concentration: 3 nM
Beside the measured number, compound 4's estimate is 20-fold (1.30 log units) above it, outside the stated range (below it).
By their numbers in this assay, from the lowest: compound 4; then compound 3; then compounds 2 and 1 (each within the scatter of the next).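

In this assay, a low number at this aromatic carbon turns out not to depend on methanesulfonamido: chloro, a single heavy atom with no hydrogen-bond donor or acceptor, takes the place of a group of 5 heavy atoms and gives a 2.7-fold lower number from compound 3 to compound 4 (0.43 log units; beyond the scatter), a modest step in the favourable direction. Compared with the earlier side groups, the 4-chlorophenyl stands far apart: in place of pyridin-4-yl it gives a 100-fold lower number from compound 2 to compound 4 (2.01 log units; beyond the scatter), and in place of tert-butyl it gives a 120-fold lower number from compound 1 to compound 4 (2.09 log units; beyond the scatter), both large steps. Nothing available explains why the single chlorine atom does better here than the larger group.

Going by these compounds alone, only two groups on this ring carbon can be compared, so it remains open whether fluoro, methoxy or a nitrile would push the number lower or higher. It also remains open how much of the low number needs any group there at all, since the plain ring with only hydrogen on that carbon is not among the compounds shown.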